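Replacing methyl with 2-phenylethenyl: working notes on compound 3

This account rests on a few compounds, and the source may have more. Where it says the series, first, only, none or still open, it means among the compounds named here.

Values so far in a functional assay on REH cells (Homo sapiens) for cytotoxicity, read by resazurin assay, with a stated time of 72 h; a higher number here means a weaker inhibitor, a lower number a stronger inhibitor
- Compound 1 `COc1cc(OC)c(C(=O)/C=C/c2ccccc2)c(OC)c1` gives > 20000 nM as a limit
- Compound 2 `COCOc1cc(OC)cc(OC)c1C(C)=O` gives > 20000 nM as a limit

Compound 2 stands at > 20000 nM as a limit of the assay and not a number. For the measured compounds named here, the measured set is summed up as the limit of > 20000 nM in this assay, at which 2 of the 2 values shown sit, and offers no step between measured compounds to work from.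

Compound 3 `COCOc1cc(OC)cc(OC)c1C(=O)/C=C/c1ccccc1` differs from compound 2 by 2-phenylethenyl in place of methyl on a carbonyl carbon. Compound 1 also carries 2-phenylethenyl on a carbonyl carbon and stands at > 20000 nM as a limit. That limit argues against expecting a large gain. A small move toward the stronger side of this assay is expected, estimated as an at least 1.3-fold lower number from compound 2 to compound 3 (0.12 log units; that floor lies within the scatter) and resting on little data. Compound 3 is estimated at 15000 nM with an expected range from 5000 nM to 30000 nM and a real chance that the assay again reports only a limit.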

Compound 3, half-maximal inhibitory concentration: 19400 nM
Compound 3: middle estimate off by 1.3-fold (0.11 log units), on the low side, and the stated range covers the measured number.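

For the compounds shown here, compound 3 gives the first number in this set rather than a limit, but that does not establish a gain: in this assay, 2-phenylethenyl in place of methyl on a carbonyl carbon gives an at least 1.0-fold lower number from compound 2 to compound 3 (0.01 log units; that floor lies within the scatter). Methoxy in place of hydrogen on a saturated chain carbon bound to an oxygen on an aromatic ring gives an at least 1.0-fold lower number from compound 1 to compound 3 (0.01 log units; that floor lies within the scatter), so neither change is shown to move the read-out beyond the scatter. Both steps are only floors, not sizes, because each starts from a compound that stands at a limit of the assay: the limit of > 20000 nM in this assay, at which 2 of the 3 values shown sit.

As far as these compounds go, how far compound 1 and compound 2 lie past their limits remains open, so the true size of either step cannot be told. Also open, from the compounds shown here alone, is whether an amine or a carboxylic acid in place of 2-phenylethenyl on a carbonyl carbon would give a number clearly away from that limit in this assay.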